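Replacing a fluorinated side chain with a cyclopentyl group

This account rests on a few compounds, and the source may have more. Where it says the series, first, only, none or still open, it means among the compounds named here.

Compound 2 `Cc1nc(S(C)(=O)=O)ccc1Oc1ncnc(OC2CCN(C(=O)O[C@H](C)C(F)(F)F)CC2)c1F` is one of two close relatives measured in a functional assay on isolated protein for inhibition of Glucose-dependent insulinotropic receptor (Rattus norvegicus), read by HTRF and cAMP accumulation (a lower number here means a smaller maximal response, a higher number a larger maximal response), where compound 2 gives 85%. Compound 1 `Cc1nc(S(C)(=O)=O)ccc1Oc1ncnc(OC2CCN(C(=O)O[C@@H](C)CF)CC2)c1F` differs from it in a single group, and in this assay compound 1 gives 84%. Within the data shown here, the step of a number 1 percentage points higher from compound 1 to compound 2 (within the scatter) lies within the scatter, so the two values cannot be told apart, and compound 2 stands level with its only neighbour.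

Compound 3 `Cc1nc(S(C)(=O)=O)ccc1Oc1ncnc(OC2CCN(C(=O)C3CCCC3)CC2)c1F` has not yet been measured. Its change from compound 2 is cyclopentyl in place of 1-(trifluoromethyl)ethoxy on a carbonyl carbon. Among the measured compounds shown here, no measured step alters the carbonyl carbon itself; the only step known, a number 1 percentage points higher from compound 1 to compound 2 (within the scatter), exchanges one fluorinated group for another and leaves the maximal response where it was. For the measured compounds named here, that step is the sole guide and argues for little movement, although the present change is larger, since the leaving group carries an oxygen and three fluorines that the entering cyclopentyl lacks. Compound 3 is therefore expected to give 80%, with a likely range from 65% to 95%. Expressed as a step, this estimate means a number 5 percentage points lower from compound 2 to compound 3 (within the scatter).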

Compound 3, largest response reached (reported as efficacy), in percent of the reference or control that the assay uses: 83%
Beside the measured number, compound 3's estimate is 3 percentage points below it; the measured number falls inside the stated range.
By their numbers in this assay, from the lowest: compounds 3, 1 and 2 (each within the scatter of the next).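

The earlier pair only exchanged one fluorinated group for another, whereas here the carbonyl carbon loses its oxygen-linked side chain altogether and carries a cyclopentyl ring instead, and in this assay that gives a number 2 percentage points lower from compound 2 to compound 3 (within the scatter). Set against the other fluorinated compound, the exchange reads the same way, as a number 1 percentage points lower from compound 1 to compound 3 (within the scatter). Among these three compounds, then, a side chain with oxygen, fluorine and a defined stereocentre and a ring of carbon only cannot be told apart at this place by maximal response, and no outside measurement is available to explain the result.

The compounds shown leave open whether this tolerance extends to groups of another kind on the carbonyl carbon, such as a phenyl ring, a longer alkyl chain, an amine or a carboxylic acid. They also leave open whether the three compounds match in the concentration needed to reach that response, since maximal response alone says nothing about it.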